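The compounds below may be only part of what the source reports. "The series", "measured", "known", "first", "only" and "open" are said of these compounds alone.

Compound 1 `CCOC(=O)c1cccc(NC(=O)N[C@H](C)c2ccccc2)c1` and compound 2 `CCOC(=O)c1ccc(NC(=O)N[C@H](C)c2ccccc2)cc1` share the same atoms joined differently; how their two cores differ is not broken down here. In an ADME assay on the whole organism with Oryza sativa as the target, tested at 10 uM (a higher number here means a weaker effect of the compound at the concentration tested, a lower number a stronger effect), compound 1 gives 88% and compound 2 gives 92%, a gap within the usual scatter. Compound 3 `CC(=O)c1cccc(NC(=O)N[C@H](C)c2ccccc2)c1` differs from compound 1 by methyl in place of ethoxy on a carbonyl carbon; in this assay compound 3 gives 73%, so that a number 15 percentage points lower from compound 1 to compound 3 (beyond the scatter). Compound 4 `CC(=O)c1ccc(NC(=O)N[C@H](C)c2ccccc2)cc1` differs from compound 2 by the same change, (methyl in place of ethoxy on a carbonyl carbon), which occurs twice among these compounds. Resting on the step of a number 15 percentage points lower from compound 1 to compound 3 (beyond the scatter), compound 4 is expected to show a number 15 percentage points lower from compound 2 to compound 4 (beyond the scatter) in this assay. The estimate for compound 4 is therefore 77%, expected to lie between 65% and 89%.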

Compound 4, a percentage reported as activity, at one concentration (the size of the read-out at that concentration, not a potency): 84%
The estimate for compound 4 lay 7 percentage points below the measured number; low and high end bracket the measured number.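

In this assay, the change from ethoxycarbonyl to acetyl gives a number 8 percentage points lower from compound 2 to compound 4 (within the scatter). Set beside the earlier step, the two cores cannot be told apart for this change: the same change on two cores in this assay, a number 15 percentage points lower (beyond the scatter) from compound 1 to compound 3 and a number 8 percentage points lower (within the scatter) from compound 2 to compound 4, 7 percentage points apart, within the scatter of two such steps. So the change carries from one core to the other without a measurable difference in its size, but this rests on only two pairs, one step lying beyond the scatter and the other within it, and it does not show that the step is truly the same on both cores or that it would hold on a third.

The compounds shown leave open how this assay would read with a longer chain, an amine or a carboxylic acid on that carbonyl carbon. They also leave open whether such groups would follow the same course on both cores.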